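Thiophen-2-yl in place of 2-methylphenyl

This account rests on a few compounds, and the source may have more. Where it says the series, first, only, none or still open, it means among the compounds named here.

In a functional assay on U-937 cells (Homo sapiens), read by cAMP accumulation (on this read-out higher numbers stand for an effect only at larger amounts of compound and lower numbers for an effect already at smaller amounts), compound 1 `CCc1nn(C2CCCC2)c2c1CCN(c1cccc(OC)c1)C2=O` gives 330 nM and compound 2 `CCc1nn(C2CCCC2)c2c1CCN(c1ccccc1C)C2=O` gives 330 nM as well, so compound 2 stands level with compound 1. Compound 3 `CCc1nn(C2CCCC2)c2c1CCN(c1cccs1)C2=O` carries thiophen-2-yl in place of 2-methylphenyl on an amide-type nitrogen in a ring. Among the compounds with values here, the only measured step at this place is no change at the digits printed from compound 1 to compound 2 (within the scatter) and neither of its groups is thiophen-2-yl, so the guide is thin. In this assay no step beyond the scatter is expected, and the estimate means a 1.1-fold lower number from compound 2 to compound 3 (0.04 log units; within the scatter) here. Compound 3 is estimated at 300 nM (expected range 100 nM to 900 nM).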

Compound 3, half-maximal effective concentration: 1 nM
For compound 3 the middle estimate is 300-fold (2.48 log units) above the measured one; the whole stated range lies above it.
By their numbers in this assay, from the lowest: compound 3; then compounds 1 and 2 (each within the scatter of the next).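

In this assay thiophen-2-yl on the amide-type nitrogen in a ring brings a 330-fold lower number from compound 2 to compound 3 (2.52 log units; beyond the scatter) and a 330-fold lower number from compound 1 to compound 3 (2.52 log units; beyond the scatter) against two substituted phenyl groups that had stood level. This place can therefore move the number very far, which the 2-methylphenyl and 3-methoxyphenyl pair gave no sign of. Nothing available accounts for the lower number. Open, going by these compounds, is whether the step follows the five-membered ring or its sulfur atom, a question for furan-2-yl or thiazol-2-yl at this place. Also open, on these data alone, is whether a methyl or chlorine on the thiophene ring keeps the low number.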